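A Methyl Step Repeated on a Second Ring

The source may report more compounds than this note shows. Statements on the series, on what has been measured and on what is new or still open speak of the compounds shown alone.

Compound 1, `N#Cc1cc(F)cc(C(=O)Nc2ccccn2)c1`, in an in vitro functional assay on HEK293-A cells for antagonist activity at metabotropic glutamate receptor 5 (Rattus norvegicus), read by calcium flux (a lower number here means a stronger inhibitor, a higher number a weaker inhibitor), gives 3010 nM.
Compound 2, `Cc1ccnc(NC(=O)c2cc(F)cc(C#N)c2)c1`, in this assay reaches only a limit of the assay, > 10000 nM.
Compound 3, `Cc1cnc(NC(=O)c2cc(F)cc(C#N)c2)s1`, in this assay gives 863 nM.

The step of an at least 3.3-fold higher number from compound 1 to compound 2 (0.52 log units; beyond the scatter) arises from methyl in place of hydrogen on an aromatic carbon, and the limit of > 10000 nM in this assay, at which 1 of the 3 values shown sits, marks where compound 2 sits. The two cores differ by 5-methyl-1,3-thiazol-2-yl in place of pyridin-2-yl on an amide-type nitrogen, which produced a 3.5-fold lower number from compound 1 to compound 3 (0.54 log units; beyond the scatter). Compound 4, `Cc1nc(NC(=O)c2cc(F)cc(C#N)c2)sc1C`, is not yet measured; it differs from compound 3 by methyl in place of hydrogen on an aromatic carbon. This is the same kind of change as that from compound 1 to compound 2, though not the same: there the methyl entered meta to a large group, opposite the ring nitrogen, here it enters next to the ring nitrogen and next to the ring atom that bears a methyl group. Because the earlier step of an at least 3.3-fold higher number from compound 1 to compound 2 (0.52 log units; beyond the scatter) weakened inhibition, compound 4 is expected to show a 2.1-fold higher number from compound 3 to compound 4 (0.32 log units; beyond the scatter). Compound 4 is therefore estimated at 1800 nM, expected to lie between 600 nM and 6000 nM.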

Compound 4, half-maximal inhibitory concentration: 594 nM
Beside the measured number, compound 4's estimate is 3.0-fold (0.48 log units) above it; the whole stated range lies above it.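

Putting a methyl on the core of compound 3 gave a 1.5-fold lower number from compound 3 to compound 4 (0.16 log units; within the scatter), so compound 3 and compound 4 cannot be told apart in this assay. The same change therefore did not carry over unchanged from one core to the other: the same change on two cores in this assay, an at least 3.3-fold higher number (0.52 log units; beyond the scatter) from compound 1 to compound 2 and a 1.5-fold lower number (0.16 log units; within the scatter) from compound 3 to compound 4, at least 4.8-fold (0.68 log units) apart, beyond the scatter of two such steps. This does not show why the two steps differ, and with a single pair on each core and the methyl placed differently on each, it gives no general rule for other cores.

As far as these compounds go, it remains open how the methyl step would read at other ring carbons of the core of compound 1. Also open, from the compounds shown here alone, is whether an ethyl chain, a trifluoromethyl group or an amine in that place on the core of compound 3 would move the number in this assay.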